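Swapping an aryl amide for a dimethylpyridinyl amide

This account rests on a few compounds, and the source may have more. Where it says the series, first, only, none or still open, it means among the compounds named here.

Compound 1 `COc1cc2nc(C)cc(OCC(=O)Nc3cc(C)cc(C)c3)c2cc1OC` gives 4.84 in a physicochemical assay for lipophilicity, read by HPLC, in phosphate buffer, measured as chromatographic lipophilicity, at pH 7.4; a higher number here means a more lipophilic compound, a lower number a more polar compound. Compound 2 `COc1ccc2nc(C)cc(OCC(=O)Nc3cc(C)ccc3OC)c2c1` gives 5.65, the higher of the two values, with compound 1 lying lower by more than the usual scatter. Compound 3 `COc1ccc2nc(C)cc(OCC(=O)Nc3c(C)cncc3C)c2c1` has not been measured; it differs from compound 2 in one place: 3,5-dimethylpyridin-4-yl in place of 2-methoxy-5-methylphenyl on an amide-type nitrogen. For the measured compounds named here, with no measured pair showing this change, the expectation rests on the change alone: a drop beyond the scatter is expected, a number 1.35 log units lower from compound 2 to compound 3 (beyond the scatter). Compound 3 is therefore estimated at 4.3, within a range from 3.6 to 5.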

Compound 3, distribution coefficient: 3.01
Estimate against measurement, compound 3: 1.29 log units above, and the stated range ends above it.
By their numbers in this assay, from the lowest: compound 3; then compound 1; then compound 2.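

In this assay, the group on the amide-type nitrogen has a strong influence on the reading: 3,5-dimethylpyridin-4-yl in place of 2-methoxy-5-methylphenyl gives a number 2.64 log units lower from compound 2 to compound 3 (beyond the scatter). For the compounds shown here, this is the first change at a single place, so it is the first direct measure of what this position can do. No measurement here explains the size of the step. As far as these compounds go, the swap changes the ring atoms and the ring's substituents together, so the share of each remains open. A plain pyridin-4-yl group at this position could begin to separate them.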